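The source may report more compounds than this note shows. Statements on the series, on what has been measured and on what is new or still open speak of the compounds shown alone.

Compound 1, `Cc1nnc(SCc2ccccc2)n1N1C(=O)c2ccccc2C1=O`. In a functional assay on HepG2 cells (Homo sapiens) for cytotoxicity, read by MTT assay, with a stated time of 48 h (a lower number here means a stronger inhibitor, a higher number a weaker inhibitor), compound 1 gives > 200000 nM, which is a limit of the assay.
Compound 2, `Cc1nnc(SCC(=O)c2ccc(Cl)cc2)n1N1C(=O)c2ccccc2C1=O`. In this assay compound 2 gives > 200000 nM, again only a limit.
Compound 3, `CCc1nnc(SCc2ccccc2)n1N1C(=O)c2ccccc2C1=O`. In this assay compound 3 gives > 200000 nM, once more a limit rather than a number.

Compound 3 therefore stands nowhere in particular on the numbers shown: its value is a limit, and the two other values are limits as well. The two steps that connect the measured compounds, a step that the two limits leave unreadable from compound 1 to compound 2 and a step that the two limits leave unreadable from compound 1 to compound 3, are unreadable for the same reason, since each joins two limits. The only firm point is the limit of > 200000 nM in this assay, at which 3 of the 3 values shown sit.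

Compound 4, `CCOC(=O)CSc1nnc(CC)n1N1C(=O)c2ccccc2C1=O`, is reached from compound 3 by one change: ethoxycarbonyl in place of phenyl on a saturated chain carbon bound to a sulfur. Neither measured step touches this part of the molecule, so nothing measured bears on it directly; the change at this position is simply untested. With every neighbour sitting at the same limit, the step from compound 3 to compound 4 is expected to be a number no higher from compound 3 to compound 4 (the limit leaves the size open), that is, no readable step at all.

Compound 4 is accordingly expected to give about 200000 nM in this assay, with a range from 60000 nM to 200000 nM, and most likely only another limit.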

Compound 4, half-maximal inhibitory concentration: > 200000 nM
Compound 4: no number, only a limit (the forecaster's own chance of this, stated with the estimate: 80%); the middle value sits exactly at the limit.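

Compound 4 gives only a limit, like compound 3, so the step between these two compounds cannot be read and no new comparison arises: the limit of > 200000 nM in this assay, at which 4 of the 4 values shown sit. The compounds shown leave open how large any step among compound 1, compound 2, compound 3 and compound 4 is in this assay, as none of them has a measured number there.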